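The source may report more compounds than this note shows. Statements on the series, on what has been measured and on what is new or still open speak of the compounds shown alone.

Compound 1 `COc1cccc(NC(=O)CSc2nc(Nc3ccccc3)c3ccccc3n2)c1` — 19400 nM
Compound 2 `C=CC(=O)Nc1cccc(NC(=O)CSc2nc(Nc3cccc([N+](=O)[O-])c3)c3ccccc3n2)c1` — 22600 nM

In a functional assay on NCI-H1975 cells (Homo sapiens) for inhibition, read by MTT assay, with a stated time of 72 h (on this read-out lower numbers stand for stronger inhibition and higher numbers for weaker inhibition), compound 2 gives 22600 nM, while compound 1 gives 19400 nM; the two numbers lie within the usual scatter of each other, so the data do not separate them. Compound 3 `C=CC(=O)Nc1cccc(NC(=O)CSc2nc(Nc3cc(OC)c(OC)c(OC)c3)c3ccccc3n2)c1` has yet to be measured in this assay. It differs from compound 2 in one place: 3,4,5-trimethoxyphenyl in place of 3-nitrophenyl on a nitrogen on an aromatic ring. Within the data shown here, no measured pair shows what this exchange does, so the step of a 1.3-fold lower number from compound 2 to compound 3 (0.10 log units; within the scatter) is expected to be small, in either direction, or none beyond the scatter. Compound 3 is therefore estimated at 18000 nM, with a range from 6000 nM to 55000 nM.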

Compound 3, half-maximal inhibitory concentration: > 50000 nM
Compound 3 ended at the assay's limit; the forecaster's own chance of this, stated with the estimate: 10%; middle value at least 2.7-fold (0.44 log units) from the limit.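

In this assay, the group on this nitrogen does matter: 3,4,5-trimethoxyphenyl in place of 3-nitrophenyl gives an at least 2.2-fold higher number from compound 2 to compound 3 (0.34 log units; beyond the scatter), so this exchange weakens inhibition. Compound 1 and compound 2 differ in more than one place and showed nothing about this position. The value of compound 3 is a limit and not a number, so the step has no known upper end: the limit of > 50000 nM in this assay, at which 1 of the 3 values shown sits.

From the compounds shown here alone, it remains open whether all three methoxy groups are needed for this loss. Also open, going by these compounds, is what an aminophenyl or a carboxyphenyl group would do on this nitrogen.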